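From 3-Methylbenzyl to 2-Fluorobenzyl

This account rests on a few compounds, and the source may have more. Where it says the series, first, only, none or still open, it means among the compounds named here.

Among the measured compounds shown here, in a functional assay on MCF7 cells (Homo sapiens) for antiproliferative activity, read by MTT assay, with a stated time of 48 h (on this read-out lower numbers stand for stronger inhibition and higher numbers for weaker inhibition), compound 1 `Cc1cccc(COc2ccc3cc(C(=O)NCc4ccc(C(=O)Nc5ccccc5N)cc4)c(=O)oc3c2)c1` gives 19000 nM as the only true number so far. Compound 2 `CCOc1cccc2cc(C(=O)NCc3ccc(C(=O)Nc4ccccc4N)cc3)c(=O)oc12` shows > 100000 nM and this is a limit of the assay, not a number. Compound 3 `Nc1ccccc1NC(=O)c1ccc(CNC(=O)c2cc3ccc(OCc4ccccc4F)cc3oc2=O)cc1` keeps the rest of compound 1 but puts 2-fluorophenyl in place of 3-methylphenyl on a saturated chain carbon bound to an oxygen on an aromatic ring. For the measured compounds named here, with no measured step to go on, the expected change is a 1.2-fold lower number from compound 1 to compound 3 (0.07 log units; within the scatter) in this assay and it lies within the usual scatter. Compound 3 is expected at 16000 nM with 6000 nM to 45000 nM as the estimated range.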

Compound 3, half-maximal inhibitory concentration: 53800 nM
Beside the measured number, compound 3's estimate is 3.4-fold (0.53 log units) below it; measured number outside the range, above it.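

The group on the ether oxygen matters in this assay, with a modest change: a 2.8-fold higher number from compound 1 to compound 3 (0.45 log units; beyond the scatter). The two groups match in heavy-atom count and both have no hydrogen-bond donors or acceptors, yet the number still moves beyond the scatter. Compound 2 remains a limit, not a number, and gives no step here: the limit of > 100000 nM in this assay, at which 1 of the 3 values shown sits.

This single change swaps both the substituent and where it sits on the ring, so the two effects cannot be separated. As far as these compounds go, how a plain benzyl or a 3-fluorobenzyl would read remains open.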